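The source may report more compounds than this note shows. Statements on the series, on what has been measured and on what is new or still open speak of the compounds shown alone.

Three aryl triazenes share one core and differ only in the group on the aromatic carbon. In a functional assay on L1210 cells (Mus musculus) for antiproliferative activity (on this read-out lower numbers stand for lower potency and higher numbers for higher potency (the scale is a negative logarithm)), compound 1 `Cc1ccc(/N=N/N(C)C)cc1` gives 3.76. Compound 2 `CN(C)/N=N/c1ccc(NC(N)=O)cc1` gives 3.97 in this assay, and compound 3 `CN(C)/N=N/c1ccc(C(N)=O)cc1` gives 3.51. Within the data shown here, compound 3 holds the lowest of the three numbers, yet the step of a number 0.25 log units lower from compound 1 to compound 3 (within the scatter) is within the scatter, and only the step of a number 0.46 log units lower from compound 2 to compound 3 (beyond the scatter) is beyond it. The remaining step, a number 0.21 log units higher from compound 1 to compound 2 (within the scatter), is also within the scatter, so the three measured numbers differ little.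

Compound 4 `CCCCN(C)/N=N/c1ccc(C(N)=O)cc1` has not been measured. It differs from compound 3 by propyl in place of hydrogen on a saturated chain carbon bound to an amine nitrogen. None of the three measured steps touches this part of the molecule: every one of them changes the group on the aromatic carbon, and the group on the amine nitrogen is the same in compound 1, compound 2 and compound 3. Among the measured compounds shown here, there is thus no measured step that bears on the change from compound 3 to compound 4, and nothing in the data points to a step in either direction beyond the scatter. The step of a number 0.01 log units lower from compound 3 to compound 4 (within the scatter) is therefore expected to be small. In this assay compound 4 is expected to give about 3.5, with a range from 2.9 to 4.1.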

Compound 4, logarithm of the reciprocal of the active concentration, log(1/C) in the L1210 assay: 3.47
Estimate against measurement, compound 4: 0.03 log units above; the measured number falls inside the stated range.
By their numbers in the L1210 assay, from the lowest: compounds 4, 3, 1 and 2 (each within the scatter of the next, the first and the last beyond it).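

Among these compounds, at the saturated chain carbon bound to an amine nitrogen, a place that none of the earlier steps touched, propyl in place of hydrogen gives in the L1210 assay a number 0.04 log units lower from compound 3 to compound 4 (within the scatter), so this place accepts the larger group without a difference in antiproliferative activity beyond the scatter. In a physicochemical assay for lipophilicity, measured as octanol-water partition (on this read-out lower numbers stand for lower lipophilicity and higher numbers for higher lipophilicity), compound 3 gives 1.2 and compound 4 gives 2.46. The same change thus separates the two compounds clearly in lipophilicity while their antiproliferative numbers stay within the scatter of each other, so across this one pair the two read-outs do not go together: the measured partition coefficient of compound 3, 1.2, and of compound 4, 2.46, a number 1.26 log units higher (beyond the scatter)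

Whether propyl at this place behaves the same way with ureido or methyl on the aromatic carbon stays open, since this change is shown only with carbamoyl there. Also open, as far as these compounds go, is what a longer chain such as hexyl, or a chain ending in an amine or a carboxylic acid, would give at this place, and one pair cannot say whether antiproliferative activity stays level over a wider span of partition coefficients.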